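Swapping chloro for methoxy at the assay limit

The source may hold more compounds than are shown below. What is called first, only, known or untested is meant among the compounds shown, and "the series" means these compounds.

- Compound 1 `CCN1CCN(CC(=O)N(Cc2ccc(OC)cc2)c2cc(OC)c(OC)c(OC)c2)CC1` gives > 20000 nM (a limit)
- Compound 2 `COc1ccc(CN(C(=O)CSC(=S)N2CCN(C(=O)OC(C)(C)C)CC2)c2ccc(Cl)cc2)cc1` gives > 20000 nM (a limit)

Both compounds were tested in a functional assay on MGC-803 cells (Homo sapiens) for inhibition, read by CCK-8 assay, with a stated time of 48 h (on this read-out higher numbers stand for weaker inhibition and lower numbers for stronger inhibition), and neither gave a number. For the measured compounds named here, in that test, compound 2 stands at a limit (> 20000 nM), and the only evidence is the limit of > 20000 nM in this assay, at which 2 of the 2 values shown sit, so far. Compound 3 `COc1ccc(CN(C(=O)CSC(=S)N2CCN(C(=O)OC(C)(C)C)CC2)c2ccc(OC)cc2)cc1` has methoxy in place of chloro on an aromatic carbon, para to a large group (methoxy in place of chloro on an aromatic carbon). Going by the values given here, no measured step shows the size of such a change. Compound 2 offers only a limit (> 20000 nM), so no step beyond the scatter is expected in this assay in either direction. The expected step runs (a number no higher from compound 2 to compound 3 (the limit leaves the size open)). For compound 3 the estimated value is 20000 nM within a range of 7000 nM to 40000 nM as expected bounds.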

Compound 3, half-maximal inhibitory concentration: > 20000 nM
Compound 3: no number, only a limit; the forecaster's own chance of this, stated with the estimate: 65%; the middle value lies on the limit itself.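

Compound 2 and compound 3 both stand at a limit in this assay, so no step between them can be read: the limit of > 20000 nM in this assay, at which 3 of the 3 values shown sit.

With no actual number among the compounds shown, whether methoxy in place of chloro changes inhibition at all remains open.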